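Cytotoxicity notes on a small amide series

The source may hold more compounds than are shown below. What is called first, only, known or untested is meant among the compounds shown, and "the series" means these compounds.

Measured in an ADME assay on H9c2 cells (Rattus norvegicus) for cytotoxicity; on this read-out lower numbers stand for stronger inhibition and higher numbers for weaker inhibition:
compound 1, `CC(C)C(=O)Nc1nc2ccc(Cl)cc2s1` — > 50000 nM, a limit of the assay, not a number
compound 2, `CC(C)(C)C(=O)Nc1nc2ccc(Cl)cc2s1` — > 50000 nM, a limit of the assay
compound 3, `CN(C(=O)C1CC1)c1nc2ccc(Cl)cc2s1` — > 50000 nM, a limit of the assay

The change from compound 1 to compound 2 is methyl in place of hydrogen on a saturated chain carbon bound to a carbonyl carbon and two saturated chain carbons; it gives a step that the two limits leave unreadable from compound 1 to compound 2, as both values are limits. The difference between the core of compound 1 and the core of compound 3 is not broken down here. Compound 4, `CCN(C(=O)C1CC1)c1nc2ccc(Cl)cc2s1`, is not yet measured; it differs from compound 3 by methyl in place of hydrogen on a saturated chain carbon bound to an amide-type nitrogen, the same kind of change as from compound 1 to compound 2, though here the place is a saturated chain carbon bound to an amide-type nitrogen rather than one bound to a carbonyl carbon and two saturated chain carbons. Because (the limit of > 50000 nM in this assay, at which 3 of the 3 values shown sit), a number for compound 4 in this assay is not expected; the expected step is a step that the limit leaves unreadable from compound 3 to compound 4. For compound 4 in this assay the estimate is 60000 nM, between 15000 nM and 250000 nM, most likely again reported only as a limit.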

Compound 4, half-maximal inhibitory concentration: > 50000 nM
Compound 4 was reported as a limit; the forecaster's own chance of this, stated with the estimate: 85%; the middle value is on the limit's open side.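

No step can be read from compound 3 to compound 4, since both values are limits: the limit of > 50000 nM in this assay, at which 4 of the 4 values shown sit. The compounds shown leave open how far each lies from that limit in this assay and which change would give a number.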